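This account rests on a few compounds, and the source may have more. Where it says the series, first, only, none or still open, it means among the compounds named here.

In a functional assay on HCT-15 cells (Homo sapiens) for inhibition (a lower number here means a stronger inhibitor, a higher number a weaker inhibitor), compound 1 (`Oc1cccc(-c2cc(-c3ccccc3F)cc(-c3ccccc3O)n2)c1`) gives 8470 nM and compound 3 (`Oc1cccc(-c2cc(-c3ccccc3F)cc(-c3cccc(O)c3)n2)c1`) gives 5300 nM, and these two values lie within the scatter of each other: a 1.6-fold lower number from compound 1 to compound 3 (0.20 log units; within the scatter). Compound 2 (`Oc1ccc(-c2cc(-c3ccccc3F)cc(-c3ccccc3O)n2)cc1`) reads > 50000 nM, which is a limit and not a number. That limit gives an at least 5.9-fold higher number from compound 1 to compound 2 (0.77 log units; beyond the scatter). Compound 4 (`Oc1cccc(-c2cc(-c3ccc(C(F)(F)F)cc3)cc(-c3ccccc3O)n2)c1`) is changed elsewhere: 4-(trifluoromethyl)phenyl in place of 2-fluorophenyl on an aromatic carbon. Both measured steps alter a hydroxyphenyl group and leave the 2-fluorophenyl untouched, so neither sizes this change directly. For the measured compounds named here, the step to compound 2 shows only that one change can matter, so no direction is expected and the range stays wide. The expected change is no more than the scatter, with a 1.2-fold lower number from compound 1 to compound 4 (0.08 log units; within the scatter) as the estimated step. For compound 4 the estimated value is 7000 nM, within an expected range of 2000 nM to 25000 nM.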

Compound 4, half-maximal inhibitory concentration: > 50000 nM
Compound 4 ended at the assay's limit (the forecaster's own chance of this, stated with the estimate: 12%); middle value at least 7.1-fold (0.85 log units) from the limit.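

Replacing 2-fluorophenyl with 4-(trifluoromethyl)phenyl, opposite the ring nitrogen, is the first change shown at this position, and it is not silent in this assay: the result is an at least 5.9-fold higher number from compound 1 to compound 4 (0.77 log units; beyond the scatter). Going by these compounds, compound 4 reads > 50000 nM, a limit and not a number, so the true size of the step stays unknown. This limit recurs in the series: the limit of > 50000 nM in this assay, at which 2 of the 4 values shown sit.

The compounds shown do not separate the change of substituent from the change in where it sits on the phenyl ring. On these data alone, how a plain phenyl, a 4-fluorophenyl or an amine-bearing phenyl would read here remains open.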